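The compounds below may be only part of what the source reports. "The series", "measured", "known", "first", "only" and "open" are said of these compounds alone.

Measured compounds:
compound 1, `CC(O)(CS(=O)(=O)c1ccc(S(F)(F)(F)(F)F)cc1)C(=O)Nc1ccc(C#N)cc1C(F)(F)F`, 17800 nM
compound 2, `CC(O)(CS(=O)(=O)c1ccc(S(F)(F)(F)(F)F)cc1)C(=O)Nc1ccc([N+](=O)[O-])cc1C(F)(F)F`, 12500 nM
compound 3, `CC1(C)C(=O)N(c2ccc(C#N)cc2C(F)(F)F)C(=S)N1c1cccc(S(F)(F)(F)(F)F)c1`, 4100 nM

Three compounds were measured in a functional assay on LNCaP cells (Homo sapiens) for antiproliferative activity, read by propidium iodide staining, with a stated time of 96 h; a higher number here means a weaker inhibitor, a lower number a stronger inhibitor. Compound 1 gives 17800 nM, and compound 2, which carries the change (nitro in place of cyano on an aromatic carbon), gives 12500 nM, a step of a 1.4-fold lower number from compound 1 to compound 2 (0.15 log units; within the scatter). Compound 3 is built on a different core, and the difference between the two cores is not broken down here; in this assay compound 3 gives 4100 nM, the lowest of the three numbers and beyond the scatter from both of the others.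

Compound 4, `CC1(C)C(=O)N(c2ccc([N+](=O)[O-])cc2C(F)(F)F)C(=S)N1c1cccc(S(F)(F)(F)(F)F)c1`, is not yet measured. It is derived from compound 3 by nitro in place of cyano on an aromatic carbon, the same change that leads from compound 1 to compound 2, on a ring described in the same words. Among the compounds with values here, the only guide to its size is the single step of a 1.4-fold lower number from compound 1 to compound 2 (0.15 log units; within the scatter), which stayed within the scatter. On that basis the step from compound 3 to compound 4 is expected to be a 1.4-fold lower number from compound 3 to compound 4 (0.14 log units; within the scatter), of about the same size. Compound 4 is therefore estimated at 3000 nM in this assay, expected to lie between 1500 nM and 6000 nM.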

Compound 4, half-maximal inhibitory concentration: 5300 nM
The estimate for compound 4 lay 1.8-fold (0.25 log units) below the measured number; measured number inside the range.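

On the core of compound 3, nitro in place of cyano on an aromatic carbon gives a 1.3-fold higher number from compound 3 to compound 4 (0.11 log units; within the scatter) in this assay, so on this core, as on the core of compound 1, the change leaves the number within the scatter. Set side by side, the two steps cannot be told apart, and the change carries across these two cores as a step too small to read: the same change on two cores in this assay, a 1.4-fold lower number (0.15 log units; within the scatter) from compound 1 to compound 2 and a 1.3-fold higher number (0.11 log units; within the scatter) from compound 3 to compound 4, 1.8-fold (0.27 log units) apart, within the scatter of two such steps. This does not show that the swap is without effect on other cores, since it rests on two pairs in a single assay, and it gives no ground for reading anything into the small differences between the two steps.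

The compounds shown leave open whether a chlorine, an amine or a carboxylic acid on that same aromatic carbon would also stay within the scatter of the cyano compounds. They also leave open whether the nitro and cyano pair would stay this close on any third core or in this assay at another stated time.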